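The compounds below may be only part of what the source reports. "The series", "measured", "known", "first", "only" and "open" are said of these compounds alone.

Measured compounds:
Compound 1 `ClCc1cccc(Cn2cnc3c(Cl)nc(Cl)nc32)c1`: > 100000 nM
Compound 2 `ClCc1ccccc1Cn1cnc2ncnc(Cl)c21`: > 100000 nM

In a functional assay on MCF7 cells (Homo sapiens) for cytotoxicity, read by sulforhodamine B assay, with a stated time of 48 h (on this read-out higher numbers stand for lower toxicity in this test and lower numbers for higher toxicity in this test), compound 1 gives > 100000 nM, which is a limit of the assay and not a number. In this assay compound 2 gives > 100000 nM, again a limit rather than a number. Compound 2 therefore stands at the limit of > 100000 nM in this assay, at which 2 of the 2 values shown sit.

Compound 3 `ClCc1ccccc1Cn1cnc2nc(Cl)nc(Cl)c21` differs from compound 2 by chloro in place of hydrogen on an aromatic carbon. For the measured compounds named here, no two measured compounds differ in one place, so no measured step sets a scale for this change. Compound 1 carries chloro on its core as well and in this assay gives > 100000 nM, a limit.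

For compound 3 the step of a number no higher from compound 2 to compound 3 (the limit leaves the size open) is expected to be none beyond the scatter. Compound 3 is estimated at 100000 nM, with a range from 50000 nM to 200000 nM, most likely reported as a limit once more.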

Compound 3, concentration lethal to 50% of the cells: > 100000 nM
Compound 3 gave a limit, no number; the forecaster's own chance of this, stated with the estimate: 85%; the middle value sits exactly at the limit.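

For the compounds shown here, compound 2 and compound 3 each give a limit of the assay and not a number in this assay, so no step between them can be read. The compounds shown leave open what chloro in place of hydrogen on an aromatic carbon does to this read-out, and whether any compound in the series gives a number: the limit of > 100000 nM in this assay, at which 3 of the 3 values shown sit.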